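The source may hold more compounds than are shown below. What is called first, only, known or untested is meant among the compounds shown, and "the series" means these compounds.

Compound 1, with the structure `C#C[C@@]1(O)[C@@H](CO)O[C@@H](n2cc(Br)c3c(N)ncnc32)[C@@H]1O`, is the starting point of this comparison. In a functional assay on L1210 cells (Mus musculus) for antiproliferative activity, read by cell counting, with a stated time of 48 h (on this read-out lower numbers stand for stronger inhibition and higher numbers for weaker inhibition), compound 1 gives 28 nM. Compound 2, with the structure `C#C[C@@]1(O)[C@@H](CO)O[C@@H](n2cc(I)c3c(N)ncnc32)[C@@H]1O`, differs from compound 1 by one change, (iodo in place of bromo on an aromatic carbon), and in this assay compound 2 gives 56 nM. The step is a 2.0-fold higher number from compound 1 to compound 2 (0.30 log units; within the scatter), so on this evidence the exchange of bromo for iodo leaves the result essentially unchanged.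

Compound 3, with the structure `C#C[C@@]1(O)[C@@H](CO)O[C@@H](n2cc(Br)c3c(Cl)ccnc32)[C@@H]1O`, carries a different core; how the two cores differ is not broken down here. In this assay compound 3 gives 30000 nM, a far weaker result than either compound 1 or compound 2.

Compound 4, with the structure `C#C[C@@]1(O)[C@@H](CO)O[C@@H](n2cc(I)c3c(Cl)ccnc32)[C@@H]1O`, has not yet been measured. It stands to compound 3 as compound 2 stands to compound 1, by the change (iodo in place of bromo on an aromatic carbon), and the place of the change is described in the same words in both pairs, so it is the same change made on the other core. Compound 4 is therefore expected to show a step of a 1.5-fold higher number from compound 3 to compound 4 (0.18 log units; within the scatter), a judgement that rests on the earlier step of a 2.0-fold higher number from compound 1 to compound 2 (0.30 log units; within the scatter), which lay within the scatter. Since compound 3 sits so high, the estimate for compound 4 also carries some chance that only a limit is reported. Compound 4 is estimated at 45000 nM. The range for compound 4 is expected to run from 15000 nM to 150000 nM.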

Compound 4, half-maximal inhibitory concentration: 20000 nM
Beside the measured number, compound 4's estimate is 2.3-fold (0.35 log units) above it, and the stated range covers the measured number.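

Iodo in place of bromo on the core of compound 3 gives a 1.5-fold lower number from compound 3 to compound 4 (0.18 log units; within the scatter) in this assay, so on this core, as on the core of compound 1, the exchange taken alone leaves the result essentially unchanged. Set side by side, however, the two steps run in opposite directions, and they do not match closely enough to count as one and the same effect on both cores: the same change on two cores in this assay, a 2.0-fold higher number (0.30 log units; within the scatter) from compound 1 to compound 2 and a 1.5-fold lower number (0.18 log units; within the scatter) from compound 3 to compound 4, 3.0-fold (0.48 log units) apart, beyond the scatter of two such steps This is a single comparison between two cores, so it does not give a rule for any other core, and it does not show why the change reads differently on these two.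

The compounds shown carry only bromo or iodo on this aromatic carbon of the five-membered ring, so it stays open how a nitrile, a carboxylic acid or a longer carbon chain would read at that place on either core. The differences between the two cores also come together in these compounds, so it remains open which of those differences accounts for the gap between the two pairs of compounds.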